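The source may report more compounds than this note shows. Statements on the series, on what has been measured and on what is new or still open speak of the compounds shown alone.

Working notes on the series. Of the compounds shown here, two carry numbers so far. Among the measured compounds shown here, compound 1 `C=CCn1c(=O)/c(=C\c2cc(F)ccc2C)[nH]c(=O)/c1=C\c1ccccc1OC` and compound 2 `COc1ccccc1/C=c1/[nH]c(=O)/c(=C\c2nc[nH]c2C(C)(C)C)[nH]c1=O` share the core but differ in several places at once, so no single step connects them. In a functional assay on BGC-823 cells (Homo sapiens) for cytotoxicity, read by CCK-8 assay, with a stated time of 72 h (a higher number here means a weaker inhibitor, a lower number a stronger inhibitor), compound 1 gives 1600 nM, the highest of the two numbers; compound 2 gives 90 nM in this assay, and the gap between the two lies well beyond the usual scatter, but with several changes at once it cannot be assigned to any one of them.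

Compound 3 `C=CCn1c(=O)/c(=C\c2ccccc2Cl)[nH]c(=O)/c1=C\c1ccccc1OC` is derived from compound 1 by 2-chlorophenyl in place of 5-fluoro-2-methylphenyl on a double-bonded chain carbon bound to an aromatic carbon. For the measured compounds named here, no measured pair shows this exchange, so nothing anchors its size. The expectation is a small step in this assay, a 1.3-fold lower number from compound 1 to compound 3 (0.12 log units; within the scatter), not clearly beyond the scatter in either direction. Compound 3 is accordingly estimated at 1200 nM in this assay, with a range from 400 nM to 4000 nM.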

Compound 3, half-maximal inhibitory concentration: 4600 nM
Estimate against measurement, compound 3: 3.8-fold (0.58 log units) below; measured number above the stated range.
By their numbers in this assay, from the lowest: compound 2; then compound 1; then compound 3.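

In this assay the series now has its first reading of a single change: 2-chlorophenyl in place of 5-fluoro-2-methylphenyl on a double-bonded chain carbon bound to an aromatic carbon gives a 2.9-fold higher number from compound 1 to compound 3 (0.46 log units; beyond the scatter). This position therefore responds to an exchange between two substituted phenyl groups, which the earlier pair, differing in several places at once, could not show. Nothing measured on these compounds speaks to the origin of this step.

Because the exchange swaps the whole group, this one step cannot separate the part played by the fluoro, the methyl and the chloro substituents. Also open, as far as these compounds go, is how this position would read with a plain phenyl group, or with a phenyl group carrying an amine or a carboxylic acid.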